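This account rests on a few compounds, and the source may have more. Where it says the series, first, only, none or still open, it means among the compounds named here.

Three analogues share one core: compound 1 `Cc1ccc(-c2nn(-c3ccccc3)cc2-c2nc3ccccc3n2S(=O)(=O)c2ccc(F)cc2)cc1`, compound 2 `Cc1ccc(-c2nn(-c3ccccc3)cc2-c2nc3ccccc3n2S(=O)(=O)c2ccc(Cl)cc2)cc1` and compound 3 `Cc1ccc(-c2nn(-c3ccccc3)cc2-c2nc3ccccc3n2S(=O)(=O)c2ccc(Br)cc2)cc1`. In an ADME assay on cells (Hepatocyte, Mus musculus) for cytotoxicity, read by MTT assay, with a stated time of 24 h (on this read-out higher numbers stand for lower toxicity in this test and lower numbers for higher toxicity in this test), compound 1 gives 167000 nM and compound 2 gives 216000 nM. As far as these compounds go, compound 3 gives > 300000 nM, which is a limit of the assay and not a number, so its exact standing is unknown.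

Compound 4 `Cc1ccc(-c2nn(-c3ccccc3)cc2-c2nc3ccccc3n2S(=O)(=O)c2ccc(C(F)(F)F)cc2)cc1` carries trifluoromethyl in place of the bromo of compound 3, on an aromatic carbon, para to a large group: trifluoromethyl in place of bromo on an aromatic carbon.

The measured steps at this same place are a 1.3-fold higher number from compound 1 to compound 2 (0.11 log units; within the scatter), an at least 1.7-fold higher number from compound 1 to compound 3 (0.25 log units; that floor lies within the scatter) and an at least 1.3-fold higher number from compound 2 to compound 3 (0.14 log units; that floor lies within the scatter). With steps of that size, no step beyond the scatter is expected in this assay, and no direction is expected either. The estimated step is an at least 1.1-fold lower number from compound 3 to compound 4 (0.06 log units; that floor lies within the scatter), and it is reckoned against a limit rather than a number. The estimated value for compound 4 is 260000 nM, with an expected range from 150000 nM to 450000 nM.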

Compound 4, half-maximal cytotoxic concentration: 89300 nM
Estimate against measurement, compound 4: 2.9-fold (0.46 log units) above, outside the stated range (below it).
By their numbers in this assay, from the lowest: compounds 4, 1 and 2 (each within the scatter of the next, the first and the last beyond it). At a limit, above all of these: compound 3.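

In this assay the group on this aromatic carbon can move the read-out beyond the scatter, which the three halogens among themselves did not show: trifluoromethyl in place of chloro gives a 2.4-fold lower number from compound 2 to compound 4 (0.38 log units; beyond the scatter). Trifluoromethyl in place of fluoro gives a 1.9-fold lower number from compound 1 to compound 4 (0.27 log units; within the scatter), so compound 4 and compound 1 remain unseparated in this test. Compound 3 holds a limit of the assay and not a number, > 300000 nM, so an at least 3.3-fold lower number from compound 3 to compound 4 (0.52 log units; beyond the scatter) is only a floor: the limit of > 300000 nM in this assay, at which 1 of the 4 values shown sits.

As far as these compounds go, whether the lower number is particular to trifluoromethyl or extends to other groups on this carbon, such as a nitrile, a methoxy group or an amine, stays open. The true value of compound 3 and the cause of the step also remain unknown.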